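The compounds below may be only part of what the source reports. "The series", "measured", "known", "first", "only" and "open" are said of these compounds alone.

Working notes on the oxazole ketone series.

Two compounds have a number in an assay for inhibition of Fatty-acid amide hydrolase 1 (Rattus norvegicus); on this read-out higher numbers stand for weaker inhibition and lower numbers for stronger inhibition. Compound 1, `COC(=O)c1cnc(C(=O)CCc2ccc(COc3ccccc3)cc2)o1`, gives 1.6 nM in this assay. Compound 2, `NC(=O)c1cccc(-c2cnc(C(=O)CCc3ccc(-c4ccccc4)cc3)o2)n1`, gives 1.2 nM in this assay, and the two values sit within the usual scatter of each other, so nothing can be said about an order between them. Within the data shown here, compound 1 and compound 2 differ at two places at once, in the group on the five-membered ring and in the tail of the chain, so no single step between them is defined.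

The next compound takes compound 2 as its point of departure. Compound 3, `COC(=O)c1cnc(C(=O)CCc2ccc(-c3ccccc3)cc2)o1`, keeps the chain and tail of compound 2 and changes only the ring substituent: methoxycarbonyl in place of 6-carbamoylpyridin-2-yl on an aromatic carbon. The same methoxycarbonyl group appears in compound 1, which reaches 1.6 nM in this assay with a different tail, so the group itself is compatible with strong inhibition in the shown data. Both tails present here have given low numbers. A step from compound 2 to compound 3 of a 1.5-fold higher number from compound 2 to compound 3 (0.18 log units; within the scatter) is expected, that is, none beyond the scatter. Compound 3 is expected to give 1.8 nM in this assay, with a range from 0.7 nM to 4.5 nM.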

Compound 3, inhibition constant: 1.5 nM
For compound 3 the middle estimate is 1.2-fold (0.08 log units) above the measured one; measured number inside the range.
By their numbers in this assay, from the lowest: compounds 2, 3 and 1 (each within the scatter of the next).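

In this assay, methoxycarbonyl in place of 6-carbamoylpyridin-2-yl, on the aromatic carbon next to the ring oxygen, gives a 1.3-fold higher number from compound 2 to compound 3 (0.10 log units; within the scatter), so this position takes either a group with a six-membered aromatic ring and a hydrogen-bond donor or a group with no ring and no donor without a change that can be read. Among these compounds, compound 3 also gives the first comparison of the two tails that differs in one place only: phenyl in place of phenoxymethyl gives a 1.1-fold lower number from compound 1 to compound 3 (0.03 log units; within the scatter), so with methoxycarbonyl on the ring the two tails cannot be told apart in this assay. Nothing in the data at hand gives a reason for either reading.

All three compounds lie within the scatter of one another, so the shown data identify no group at this position that moves the number, and it remains open whether a carboxylic acid or an amine there would read the same. Also open, from the compounds shown here alone, are 6-carbamoylpyridin-2-yl combined with the phenoxymethyl tail, and a longer chain in place of the present one.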